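The source may report more compounds than this note shows. Statements on the series, on what has been measured and on what is new or still open speak of the compounds shown alone.

Series notes. Compound 1 `CNS(=O)(=O)c1ccc(-c2cnc(N)c(-c3ccc(OC)nc3)c2)cc1` stands lowest of the two compounds measured in a physicochemical assay for lipophilicity, at pH 7.4; a lower number here means a more polar compound, a higher number a more lipophilic compound: compound 1 gives 2.2, whereas compound 2 `COc1ccc(-c2cc(-c3ccc4cnn(C)c4c3)cnc2N)cn1` gives 3, a gap beyond the usual scatter. Compound 3 `COc1ccc(-c2cc(-c3ccc(C(=O)O)cc3)cnc2N)cn1` has not yet been measured in this assay; it differs from compound 1 in one place: carboxy in place of methylsulfamoyl on an aromatic carbon. Among the measured compounds shown here, no step between the measured compounds matches this change, so the direction rests on the change alone. A sizeable fall in this assay is expected, with the step of a number 1.90 log units lower from compound 1 to compound 3 (beyond the scatter) lying well beyond the scatter. Compound 3 is estimated at 0.3, within a range from -0.6 to 1.2.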

Compound 3, distribution coefficient: 0.8
Beside the measured number, compound 3's estimate is 0.50 log units below it; measured number inside the range.
By their numbers in this assay, from the lowest: compound 3; then compound 1; then compound 2.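

At the aromatic carbon para to a large group, the series now has its first single-place step: carboxy in place of methylsulfamoyl gives a number 1.40 log units lower from compound 1 to compound 3 (beyond the scatter) in this assay. The reading at this position is therefore clearly sensitive to the group it carries. No measurement shown accounts for the size of this step. With only these two groups compared here, the trend at this carbon remains undefined. A methyl ester or a primary amide at the same carbon would show whether the reading stays close to compound 3 or returns towards compound 1.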